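A Chlorinated Cyclohexyl Amide Meets a Cytotoxicity Limit

A few compounds are considered here, and "the series" means these few. Any claim that something is new, unique, unknown or untested is made for them only; others in the source may bear on it.

Of the compounds shown here, two have been measured in an ADME assay on MT4 cells (Homo sapiens) for cytotoxicity, with a stated time of 5 days; on this read-out higher numbers stand for lower toxicity in this test and lower numbers for higher toxicity in this test. Compound 1 (`CC1CC=C(C(=O)N(c2cc(C#CC(C)(C)C)sc2C(=O)O)C(C)C)CC1`) gives > 20000 nM, which is a limit of the assay and not a number. Compound 2 (`CC(C)(C)C#Cc1cc(N(C(=O)[C@H]2CC[C@H](C)CC2)[C@H]2CC[C@H](OC3CCOCC3)CC2)c(C(=O)O)s1`) gives > 20000 nM, which is also a limit. Compound 1 therefore stands at the limit of > 20000 nM in this assay, at which 2 of the 2 values shown sit, without an exact number of its own.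

Compound 3 (`CC(C)N(c1cc(C#CC(C)(C)C)sc1C(=O)O)C(=O)[C@H]1CC[C@H](Cl)CC1`) has not yet been measured. It carries 4-chlorocyclohexyl in place of 4-methylcyclohex-1-en-1-yl on a carbonyl carbon. Among the compounds with values here, no measured step is available to size this change. From compound 1 at > 20000 nM, a limit, no step beyond the scatter is expected in this assay, and neither direction is favoured. The expected step is a step that the limit leaves unreadable from compound 1 to compound 3. For compound 3 the estimated value is 22000 nM, with an expected range of 11000 nM to 45000 nM.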

Compound 3, half-maximal cytotoxic concentration: > 20000 nM
Compound 3 ended at the assay's limit (the forecaster's own chance of this, stated with the estimate: 85%); the middle value does not contradict the limit.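

No step from compound 1 to compound 3 can be read in this assay, since both compounds sit at a limit of the assay: the limit of > 20000 nM in this assay, at which 3 of the 3 values shown sit.

The compounds shown leave open whether 4-chlorocyclohexyl and 4-methylcyclohex-1-en-1-yl differ at all in this read-out, since none of the three has an exact number.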